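Shortening the Hydroxamate Chain on a Shared Core

The source may hold more compounds than are shown below. What is called first, only, known or untested is meant among the compounds shown, and "the series" means these compounds.

Compound 1, `Nc1ncnc2c1c(-c1cnc3[nH]ccc3c1)nn2CCCCCCCCC(=O)NO`: 5460 nM
Compound 2, `Nc1nc2cc(-c3nn(CC(=O)NO)c4ncnc(N)c34)ccc2o1`: 11400 nM

In a functional assay on HCT-116 cells (Homo sapiens) for inhibition, read by MTT assay, with a stated time of 72 h (a higher number here means a weaker inhibitor, a lower number a stronger inhibitor), compound 1 gives 5460 nM, the lowest of the two numbers; compound 2 gives 11400 nM, a gap beyond the scatter. Compound 3, `Nc1ncnc2c1c(-c1cnc3[nH]ccc3c1)nn2CCCC(=O)NO`, keeps the core of compound 1 with hydroxycarbamoyl in place of 5-(hydroxycarbamoyl)pentyl on a saturated chain carbon, three bonds along the chain from an aromatic nitrogen. Among the measured compounds shown here, no step between measured compounds covers this change. Because compound 2 gives 11400 nM while compound 1 gives 5460 nM, an upward step in this assay, beyond the scatter, is expected. Compound 3 is estimated at 16000 nM, between 5000 nM and 50000 nM, an expected step of a 2.9-fold higher number from compound 1 to compound 3 (0.47 log units; beyond the scatter).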

Compound 3, half-maximal inhibitory concentration: > 150000 nM
Compound 3 ended at the assay's limit; the forecaster's own chance of this, stated with the estimate: 20%; middle value at least 9.3-fold (0.97 log units) away from the limit.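

In this assay, among the compounds shown here, the change from 5-(hydroxycarbamoyl)pentyl to hydroxycarbamoyl gives an at least 27-fold higher number from compound 1 to compound 3 (1.43 log units; beyond the scatter) and is the only step here measured on one shared core, showing that this position on a saturated chain carbon is sensitive to chain length. Compound 3 gives > 150000 nM as a limit of the assay and not a number. The step therefore sets only a minimum size for this change. The compounds shown leave open how the number moves with chains of intermediate length or a longer chain, and whether a carboxylic acid or an amine could replace the terminal hydroxamic acid group.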